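The compounds below may be only part of what the source reports. "The series", "measured", "known", "first", "only" and "open" are said of these compounds alone.

Within the data shown here, compound 1 `CC1=CC[C@H](C(C)(C)NC(=S)N/N=C/c2ccccc2O)CC1` is the only compound for which an ADME assay on Vero cells (Chlorocebus sabaeus) for inhibition, read by sulforhodamine B assay, with a stated time of 48 h (on this read-out higher numbers stand for weaker inhibition of growth and lower numbers for stronger inhibition of growth), gives an actual number: in this assay compound 1 gives 11200 nM. Compound 2 `CC1=CC[C@H](C(C)(C)NC(=S)N/N=C/c2ccccc2[N+](=O)[O-])CC1` is its counterpart with a nitro group on the aromatic carbon; in this assay compound 2 gives > 100000 nM, which is a limit of the assay and not a number. That change produced an at least 8.9-fold higher number from compound 1 to compound 2 (0.95 log units; beyond the scatter).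

Compound 3 `CC1=CC[C@H](C(C)(C)NC(=S)N/N=C/c2ccco2)CC1` differs from compound 1 in one place: furan-2-yl in place of 2-hydroxyphenyl on a carbon with a double bond to nitrogen. Among the measured compounds shown here, the only measured step that bears on this is the one from compound 1 to compound 2, in which the hydroxy group was also lost and the growth-inhibiting effect grew at least modestly weaker. Since compound 3 also loses the hydroxy group, a weakening of similar order is expected, though the ring itself changes here as well. For compound 3 the expected value in this assay is 35000 nM, between 11000 nM and 100000 nM, corresponding to an expected step of a 3.1-fold higher number from compound 1 to compound 3 (0.49 log units; beyond the scatter).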

Compound 3, concentration for total growth inhibition: 14700 nM
Compound 3: the middle estimate sits 2.4-fold (0.38 log units) above what was measured; the measured number falls inside the stated range.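

In this assay, putting furan-2-yl in place of 2-hydroxyphenyl on a carbon with a double bond to nitrogen gives a 1.3-fold higher number from compound 1 to compound 3 (0.12 log units; within the scatter), so the two compounds cannot be told apart on this read-out. This position therefore accepts a smaller, five-membered aromatic ring with no hydrogen-bond donor, and the hydroxy group is not needed to keep this level of growth inhibition. Losing the hydroxy group does not by itself go with weaker growth inhibition, and the result for compound 2 is a limit and not a number: the limit of > 100000 nM in this assay, at which 1 of the 3 values shown sits.

As far as these compounds go, whether a plain phenyl, a 2-aminophenyl or a pyridin-2-yl group at this position would also stay at this level remains open. The compounds shown also leave open how much of the outcome depends on the ring and how much on the group it carries.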